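The source may hold more compounds than are shown below. What is called first, only, known or untested is meant among the compounds shown, and "the series" means these compounds.

For the measured compounds named here, compound 3 `FC(F)(F)c1ccc(CSc2nc(Nc3ccc(C(F)(F)F)cc3)c3ccccc3n2)cc1` is the only one of three analogues that returns a number in a functional assay on MCF7 cells (Homo sapiens) for cytotoxicity, read by MTT assay, with a stated time of 72 h; a lower number here means a stronger inhibitor, a higher number a weaker inhibitor: compound 3 gives 5100 nM. Compound 1 `FC(F)(F)c1ccc(CSc2nc(Nc3ccccc3Cl)c3ccccc3n2)cc1` reaches only the limit > 50000 nM in this assay. Compound 2 `CCOc1ccccc1Nc1nc(SCc2ccc(C(F)(F)F)cc2)nc2ccccc12` likewise stops at the limit > 50000 nM. Both an at least 9.8-fold lower number from compound 1 to compound 3 (0.99 log units; beyond the scatter) and an at least 9.8-fold lower number from compound 2 to compound 3 (0.99 log units; beyond the scatter) show that exchanging the aryl group on the ring nitrogen moves the number strongly. Compound 4 `COc1ccc(Nc2nc(SCc3ccc(C(F)(F)F)cc3)nc3ccccc23)cc1OC` differs from compound 3 by 3,4-dimethoxyphenyl in place of 4-(trifluoromethyl)phenyl on a nitrogen on an aromatic ring. Because an at least 9.8-fold lower number from compound 1 to compound 3 (0.99 log units; beyond the scatter) and an at least 9.8-fold lower number from compound 2 to compound 3 (0.99 log units; beyond the scatter) were both large, this exchange is expected to move the number again, here toward a weaker inhibitor. Compound 4 is estimated at 20000 nM, with a range from 5000 nM to 60000 nM. That expectation means a step of a 3.9-fold higher number from compound 3 to compound 4 (0.59 log units; beyond the scatter).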

Compound 4, half-maximal inhibitory concentration: > 50000 nM
Compound 4: only a limit was reported; the forecaster's own chance of this, stated with the estimate: 40%; middle value at least 2.5-fold (0.39 log units) from the limit.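

In this assay, 3,4-dimethoxyphenyl in place of 4-(trifluoromethyl)phenyl on this nitrogen gives an at least 9.8-fold higher number from compound 3 to compound 4 (0.99 log units; beyond the scatter). Among the four aryl groups shown here, only 4-(trifluoromethyl)phenyl gives a number, so 3,4-dimethoxyphenyl does not restore a measurable value. The steps among compound 1, compound 2 and compound 4 cannot be read, since each of these compounds stops at a limit: the limit of > 50000 nM in this assay, at which 3 of the 4 values shown sit.

The compounds shown leave open whether the trifluoromethyl group itself is what matters on this aryl ring. A nitrile or a carboxylic acid in its place could test this.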